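Replacing tert-butyl with phenethyl on the shared core

The source may hold more compounds than are shown below. What is called first, only, known or untested is meant among the compounds shown, and "the series" means these compounds.

Of the compounds shown here, three sharing one core have been measured in an in vitro functional assay on cells for agonist activity at Bombesin receptor subtype-3 (Homo sapiens), read by luminescence and calcium flux; on this read-out lower numbers stand for an effect already at smaller amounts and higher numbers for an effect only at larger amounts of compound. Compound 1 `COc1ccccc1Cc1cnc(CCc2ccc(-c3ccccc3C(=O)O)cc2)[nH]1` gives 1720 nM, compound 2 `N#Cc1cccc(Cc2cnc(CCc3ccc(-c4ccccc4C(=O)O)cc3)[nH]2)c1` gives 812 nM, and compound 3 `CC(C)(C)c1cnc(CCc2ccc(-c3ccccc3C(=O)O)cc2)[nH]1` gives 4330 nM. Compound 3 stands highest of the three numbers, shown by a 2.5-fold higher number from compound 1 to compound 3 (0.40 log units; beyond the scatter) and a 5.3-fold higher number from compound 2 to compound 3 (0.73 log units; beyond the scatter): tert-butyl in place of 2-methoxybenzyl or 3-cyanobenzyl raised the number in both cases. Compound 4 `O=C(O)c1ccccc1-c1ccc(CCc2ncc(CCc3ccccc3)[nH]2)cc1` moves the other way: phenethyl in place of tert-butyl on an aromatic carbon. Those two steps are the ones that bear on this change, and both were modest, so a modest move toward a lower number is expected here. The estimated step is a 2.9-fold lower number from compound 3 to compound 4 (0.46 log units; beyond the scatter) for compound 4. Compound 4 is expected to give about 1500 nM, within 500 nM to 4500 nM.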

Compound 4, half-maximal effective concentration: 1320 nM
The estimate for compound 4 lay 1.1-fold (0.06 log units) above the measured number, and the stated range covers the measured number.
By their numbers in this assay, from the lowest: compounds 2, 4 and 1 (each within the scatter of the next, the first and the last beyond it); then compound 3.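

In this assay, phenethyl in place of tert-butyl on the shared core lowers the number (a 3.3-fold lower number from compound 3 to compound 4 (0.52 log units; beyond the scatter)), so all three groups carrying a six-membered aromatic ring now stand below tert-butyl, with no compound shown going against this. Compound 4, with neither nitrile nor methoxy on its ring, cannot be told apart from the two substituted groups (a 1.6-fold higher number from compound 2 to compound 4 (0.21 log units; within the scatter); a 1.3-fold lower number from compound 1 to compound 4 (0.11 log units; within the scatter)). Nothing available explains these steps.

Still open, from the compounds shown here alone, is how an amine, an amide or a longer chain ending in phenyl would read at this position.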